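A few compounds are considered here, and "the series" means these few. Any claim that something is new, unique, unknown or untested is made for them only; others in the source may bear on it.

Working notes on the series, read in a physicochemical assay for permeability, using PAMPA; on this read-out higher numbers stand for higher permeability and lower numbers for lower permeability. Within the data shown here, compound 1 `Cc1ccc(-c2nc(CN3CCC(C(=O)NCCCN4C[C@H](C)C[C@H](C)C4)CC3)c(C)o2)cc1` gives 274 10^-6 cm/s and compound 2 `Cc1cccc(C)c1-c1nc(CN2CCC(C(=O)NCCCN3C[C@H](C)C[C@H](C)C3)CC2)c(C)o1` gives 254 10^-6 cm/s, so compound 2 stands within the scatter of compound 1, the only other number so far.

Compound 3 `Cc1ccc(-c2nc(CN3CCC(C(=O)NCCCN4C[C@H](C)C[C@H](C)C4)CC3)c(C)o2)cc1C` is the next to be read. The change is 3,4-dimethylphenyl in place of 2,6-dimethylphenyl on an aromatic carbon of a five-membered aromatic ring with 1 nitrogen and 1 oxygen. Among the measured compounds shown here, no measured compound carries 3,4-dimethylphenyl yet.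

For the measured compounds named here, the one measured step that bears on this is a 1.1-fold lower number from compound 1 to compound 2 (0.03 log units; within the scatter), for 2,6-dimethylphenyl in place of 4-methylphenyl on an aromatic carbon, and it lies within the scatter. On that single step, no change beyond the scatter is expected in this assay, in either direction. The estimated step is a 1.0-fold higher number from compound 2 to compound 3 (0.01 log units; within the scatter) and it rests on this one comparison alone. In this assay the estimate for compound 3 is 260 10^-6 cm/s, with an expected range from 130 10^-6 cm/s to 500 10^-6 cm/s.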

Compound 3, apparent permeability: 219 10^-6 cm/s
Compound 3: middle estimate off by 1.2-fold (0.07 log units), on the high side; the measured number falls inside the stated range.
By their numbers in this assay, from the lowest: compounds 3, 2 and 1 (each within the scatter of the next).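

In this assay, the change to 3,4-dimethylphenyl gives a 1.2-fold lower number from compound 2 to compound 3 (0.06 log units; within the scatter); the two groups have the same atoms, joined differently, so this rearrangement of the two methyl groups on the phenyl ring produces no step beyond the scatter. Methyl in place of hydrogen on an aromatic carbon of the phenyl ring gives a 1.3-fold lower number from compound 1 to compound 3 (0.10 log units; within the scatter), which also stays within the scatter, so a second kind of change at this position, the addition of one methyl group rather than a rearrangement, can now be read as well. Across 4-methylphenyl, 2,6-dimethylphenyl and 3,4-dimethylphenyl on this aromatic carbon, all three compounds therefore remain within the scatter of one another in this read-out, and nothing available here speaks to the reason for these small steps.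

From the compounds shown here alone, all three groups at this position are phenyl rings carrying only methyl groups, so the effect of a carboxylic acid, an amine or a methoxy group on that ring remains open. Going by these compounds, whether a pyridine ring in place of the phenyl ring, or a longer chain in the amide part of the shared core, would move the number beyond the scatter also remains open.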